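Chloro in Place of Methoxy: An Expected Step for Compound 4

The source may report more compounds than this note shows. Statements on the series, on what has been measured and on what is new or still open speak of the compounds shown alone.

Compound 3 `COc1ccccc1N1CCN(CC(=O)N2CCN(c3nnc(-c4ccc(C)cc4)c(-c4ccc(C)cc4)n3)CC2)CC1` gives 133000 nM in an ADME assay on NIH3T3 cells (Mus musculus) for cytotoxicity, read by MTT assay, with a stated time of 24 h (a lower number here means a stronger inhibitor, a higher number a weaker inhibitor), the highest of the two numbers shown. Compound 1 `O=C(CN1CCN(c2ccc(Cl)cc2)CC1)N1CCN(c2nnc(-c3ccccc3)c(-c3ccccc3)n2)CC1` gives 113000 nM, a difference that lies within the scatter. For compound 2 `Cc1ccc(-c2nnc(N3CCN(C(=O)CN4CCN(c5ccccc5)CC4)CC3)nc2-c2ccc(C)cc2)cc1` this assay reports only a limit, > 914000 nM. Among the compounds with values here, the one measured step, an at least 6.8-fold lower number from compound 2 to compound 3 (0.83 log units; beyond the scatter), rests on that limit (the limit of > 914000 nM in this assay, at which 1 of the 3 values shown sits) and shows that a change at this aromatic carbon can move the number beyond the scatter. Compound 4 `Cc1ccc(-c2nnc(N3CCN(C(=O)CN4CCN(c5ccccc5Cl)CC4)CC3)nc2-c2ccc(C)cc2)cc1` differs from compound 3 by chloro in place of methoxy on an aromatic carbon. Within the data shown here, no measured pair exchanges chloro for methoxy, so no size can be read for this step. Compound 4 is therefore expected to sit near compound 3. The expected step of a 1.0-fold lower number from compound 3 to compound 4 (0.01 log units; within the scatter) lies within the scatter. Compound 4 is estimated at 130000 nM, with a range from 40000 nM to 450000 nM.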

Compound 4, half-maximal inhibitory concentration: > 859000 nM
Compound 4 ended at the assay's limit; the forecaster's own chance of this, stated with the estimate: 30%; middle value at least 6.6-fold (0.82 log units) away from the limit.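

In this assay, the change from 2-methoxyphenyl to 2-chlorophenyl gives an at least 6.4-fold higher number from compound 3 to compound 4 (0.81 log units; beyond the scatter), so on this aromatic carbon chloro does not stand in for methoxy. Until now only hydrogen had been set against methoxy here; hydrogen in compound 2 and chloro in compound 4 both end at limits of the assay, and the step between those two cannot be read. Of these three compounds, only compound 3, with methoxy, gives a number that is not a limit.

Going by these compounds, whether another group on this carbon, such as an amine or a carboxylic acid, would also give a readable number remains open. So does the size of any difference between hydrogen and chloro.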